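A few compounds are considered here, and "the series" means these few. Any claim that something is new, unique, unknown or untested is made for them only; others in the source may bear on it.

Working notes on the series. Three compounds are measured in a functional assay on NCI/ADR-RES cells (Homo sapiens) for inhibition, read by sulforhodamine B assay, with a stated time of 48 h; a higher number here means a weaker inhibitor of growth, a lower number a stronger inhibitor of growth. Compound 1 `COc1ccc(-c2cc(/C=C/C(=O)c3ccc(N)cc3)[nH]n2)cc1` gives 2860 nM. Compound 2 `COc1ccc(-c2cc(/C=C/C(=O)c3ccc(N)cc3)[nH]n2)cc1OC` gives 6210 nM. Compound 3 `COc1cc(C(=O)/C=C/c2cc(-c3cc(OC)c(OC)c(OC)c3)n[nH]2)cc(OC)c1OC` gives 3470 nM, second highest of the three numbers and within the scatter of both compound 1 and compound 2. The difference between the cores of compound 2 and compound 3 is not broken down here.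

One change has a measured step: from compound 2 to compound 1, (hydrogen in place of methoxy on an aromatic carbon), with a 2.2-fold lower number from compound 2 to compound 1 (0.34 log units; beyond the scatter). Compound 4 `COc1ccc(-c2cc(/C=C/C(=O)c3cc(OC)c(OC)c(OC)c3)[nH]n2)cc1OC` is not yet measured in this assay; it is made from compound 3 by hydrogen in place of methoxy on an aromatic carbon. The place is not identical to the earlier one, since here the carbon is also meta to a methoxy group, so this is the same kind of change rather than the same change. Going by the values given here, the expected step of a 2.0-fold lower number from compound 3 to compound 4 (0.31 log units; beyond the scatter) is set at about the size of a 2.2-fold lower number from compound 2 to compound 1 (0.34 log units; beyond the scatter), as the only measured step of this kind, with added uncertainty for the different core. Resting on compound 3 at 3470 nM and that step, compound 4 is expected to give 1700 nM, estimated to fall between 800 nM and 3600 nM.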

Compound 4, concentration for 50% growth inhibition: 2690 nM
Estimate against measurement, compound 4: 1.6-fold (0.20 log units) below, and the stated range covers the measured number.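

In this assay, hydrogen in place of methoxy on an aromatic carbon gives a 1.3-fold lower number from compound 3 to compound 4 (0.11 log units; within the scatter), a step that cannot be told apart from repeated measurement, whereas the same kind of replacement on the other core gave a 2.2-fold lower number from compound 2 to compound 1 (0.34 log units; beyond the scatter). Set side by side, the two steps do not differ beyond what such measurements allow: the same change on two cores in this assay, a 2.2-fold lower number (0.34 log units; beyond the scatter) from compound 2 to compound 1 and a 1.3-fold lower number (0.11 log units; within the scatter) from compound 3 to compound 4, 1.7-fold (0.23 log units) apart, within the scatter of two such steps. Going by these compounds alone, this gives no sign that the core alters the effect of the replacement, but it does not show that the step carries over at a fixed size, since only two pairs are available, the place on the ring is not identical, and one of the two steps lies within the scatter.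

The compounds shown leave open whether a group other than hydrogen at this place, such as hydroxyl, fluorine or a longer alkoxy chain, would give a step beyond the scatter on either core. Also open, from the compounds shown here alone, is how the replacement behaves on a core carrying a carboxylic acid in place of the amine of compound 1.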